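From methoxy to hydroxy on the shared core

This account rests on a few compounds, and the source may have more. Where it says the series, first, only, none or still open, it means among the compounds named here.

In a functional assay on HCT-116 cells (Homo sapiens) for antiproliferative activity, read by MTT assay, with a stated time of 48 h (a higher number here means a weaker inhibitor, a lower number a stronger inhibitor), compound 1 (`COc1ccc(-c2c(Nc3ccc(F)cc3)c3ccccc3oc2=O)cc1`) gives 39400 nM and compound 3 (`COc1ccc(-c2c(Nc3ccc(C)c(O)c3)c3ccc(OC)cc3oc2=O)cc1`) gives 26500 nM as values within the usual scatter of each other. Compound 2 (`COc1ccc(-c2c(Nc3ccc(F)cc3)c3ccc(OC)cc3oc2=O)cc1`) reads "not determined" (no result reported) there, with no result reported, so it holds no single number on this scale. Compound 4 (`COc1ccc(-c2c(Nc3ccc(F)cc3)c3ccc(O)cc3oc2=O)cc1`) still awaits measurement. The step hydrogen in place of methyl on an oxygen on an aromatic ring puts hydrogen in place of methyl on an oxygen on an aromatic ring, methoxy to hydroxy. No measured step sizes this change, so no shift beyond the scatter is expected in this assay and no direction is predicted. The estimate therefore stays close to the two measured values. Compound 4 is expected at about 30000 nM with an estimated range of 11000 nM to 75000 nM for the coming measurement.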

Compound 4, half-maximal inhibitory concentration: 66100 nM
The estimate for compound 4 lay 2.2-fold (0.34 log units) below the measured number; the measured number falls inside the stated range.
By their numbers in this assay, from the lowest: compounds 3, 1 and 4 (each within the scatter of the next, the first and the last beyond it).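

In this assay the methoxy to hydroxy step cannot be read, since compound 2 holds no single number. The result instead gives this position its first sized change: hydroxy in place of hydrogen on an aromatic carbon yields a 1.7-fold higher number from compound 1 to compound 4 (0.22 log units; within the scatter) and so does not separate the two compounds. No measured evidence bears on why this is so.

The compounds shown leave open how an amine or a carboxylic acid at this position would read. They also leave open whether a longer chain on this oxygen would read differently from methyl or hydrogen.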